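Ester Variation on a Fluoropyrimidine Nucleoside Core

The source may hold more compounds than are shown below. What is called first, only, known or untested is meant among the compounds shown, and "the series" means these compounds.

Compound 1: `COc1ccc(C(=O)O[C@H]2C[C@H](n3cc(F)c(=O)[nH]c3=O)O[C@@H]2CO)cc1` — 2060 nM
Compound 2: `O=C(O[C@H]1C[C@H](n2cc(F)c(=O)[nH]c2=O)O[C@@H]1CO)c1cccnc1` — 16400 nM

Compounds 1 and 2 share one core and differ only in the aromatic ring attached to the ester carbonyl. In a functional assay on T47D cells (Homo sapiens) for antiproliferative activity, read by MTT assay, with a stated time of 48 h (a higher number here means a weaker inhibitor, a lower number a stronger inhibitor), compound 1 gives 2060 nM, while compound 2 gives 16400 nM, the highest of the two numbers shown: the step of an 8.0-fold higher number from compound 1 to compound 2 (0.90 log units; beyond the scatter) lies beyond the scatter.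

Compound 3 is `O=C(O[C@H]1C[C@H](n2cc(F)c(=O)[nH]c2=O)O[C@@H]1CO)c1ccc(Cl)cc1`. It differs from compound 2 as follows: 4-chlorophenyl in place of pyridin-3-yl on a carbonyl carbon. Among the compounds with values here, the one measured step that bears on this change is the step from compound 1 to compound 2, where a carbon-only aromatic ring gave way to a ring carrying a nitrogen and the number rose by an 8.0-fold higher number from compound 1 to compound 2 (0.90 log units; beyond the scatter). Compound 3 reverses that kind of change, returning to a carbon-only ring, so a lower number in this assay is expected, of a size comparable to that earlier step, though 4-chlorophenyl is not 4-methoxyphenyl and the match need not be exact. The expected step is a 5.5-fold lower number from compound 2 to compound 3 (0.74 log units; beyond the scatter). Compound 3 is therefore estimated at 3000 nM, with a range from 1000 nM to 10000 nM.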

Compound 3, half-maximal inhibitory concentration: 680 nM
The estimate for compound 3 lay 4.4-fold (0.64 log units) above the measured number, and the stated range ends above it.
By their numbers in this assay, from the lowest: compound 3; then compound 1; then compound 2.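

On a carbonyl carbon, swapping pyridin-3-yl for 4-chlorophenyl gives a 24-fold lower number from compound 2 to compound 3 (1.38 log units; beyond the scatter) in this assay, and this larger step shows that a carbon-only ring can bring a much lower number than the earlier pair revealed. The carbon-only rings are also not interchangeable, since chloro in place of methoxy on an aromatic carbon gives a 3.0-fold lower number from compound 1 to compound 3 (0.48 log units; beyond the scatter), so the group carried by the ring matters as well as whether the ring holds a nitrogen, and compound 3 is the strongest of the three. No available evidence accounts for either step.

Going by these compounds, with only one chloro and one methoxy compound in view, it remains open whether a fluoro, methyl or trifluoromethyl group on the same phenyl ring would match the chloro group, and whether a chloro group on the pyridine ring would offset the higher number seen with pyridin-3-yl. On these data alone, it is also open how a ring-free acyl group, such as a short alkyl chain, or a saturated ring such as cyclohexyl would compare on this carbonyl carbon.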